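From phenyl to 4-carbamoylpiperidin-1-yl: a step at the limit

The source may hold more compounds than are shown below. What is called first, only, known or untested is meant among the compounds shown, and "the series" means these compounds.

In an ADME assay on J774.1 cells (Mus musculus) for cytotoxicity, read by resazurin assay, with a stated time of 48 h (a lower number here means a stronger inhibitor, a higher number a weaker inhibitor), compound 1 `CCn1cc(C(=O)NCc2ccc(OC)cc2)c(=O)c2ccc(C(F)(F)F)cc21` reads > 100000 nM as a limit of the assay. Compound 3 `CCn1cc(C(=O)O)c(=O)c2ccc(C(F)(F)F)cc21` reads > 100000 nM as a limit too. Compound 2 `CCCCn1cc(C(=O)NCc2ccccc2)c(=O)c2cc(F)c(-c3ccccc3)cc21` reads > 100000 nM as a limit as well. Compound 2 therefore stands at the limit of > 100000 nM in this assay, at which 3 of the 3 values shown sit, and offers no number to step from.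

Compound 4 `CCCCn1cc(C(=O)NCc2ccccc2)c(=O)c2cc(F)c(N3CCC(C(N)=O)CC3)cc21` carries 4-carbamoylpiperidin-1-yl in place of phenyl on an aromatic carbon, ortho to a fluoro group, a change counted as 4-carbamoylpiperidin-1-yl in place of phenyl on an aromatic carbon against compound 2. Within the data shown here, no measured step is available to size this change. In this assay no step beyond the scatter is expected, since compound 2 rests at the limit of > 100000 nM in this assay, at which 3 of the 3 values shown sit, and nothing yet measured departs from it. Should a number appear, it is expected on the lower side of that limit. The estimated size of the step of a number no higher from compound 2 to compound 4 (the limit leaves the size open) is no more than the scatter. Compound 4 is estimated at 100000 nM with an expected range of 40000 nM to 200000 nM around that figure.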

Compound 4, half-maximal inhibitory concentration: 47000 nM
For compound 4 the middle estimate is 2.1-fold (0.33 log units) above the measured one, and the stated range covers the measured number.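

In this assay, 4-carbamoylpiperidin-1-yl in place of phenyl on this aromatic carbon, ortho to a fluoro group, gives an at least 2.1-fold lower number from compound 2 to compound 4 (0.32 log units; beyond the scatter). Compound 4 gives 47000 nM, the only measured number among the compounds shown. The other compounds shown each read only a limit of the assay, so a change at this position can bring the reading off the limit, something those compounds did not show. The full size of the step stays open because compound 2 offers only a limit of the assay: the limit of > 100000 nM in this assay, at which 3 of the 4 values shown sit.

The compounds shown leave open whether a plain piperidin-1-yl, without the carbamoyl, or a morpholin-4-yl on this carbon would read like compound 4. They also leave open whether a carboxylic acid in place of the carbamoyl would keep the reading off the limit.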